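A few compounds are considered here, and "the series" means these few. Any claim that something is new, unique, unknown or untested is made for them only; others in the source may bear on it.

In a functional assay on HCT-116 cells (Homo sapiens) for antiproliferative activity, read by MTT assay, with a stated time of 72 h (on this read-out lower numbers stand for stronger inhibition and higher numbers for weaker inhibition), compound 1 `C=CC(=O)Nc1ccc(Cl)c(S(=O)(=O)N(C)C)c1` gives 24600 nM as a measured number. Compound 2 `COC(=O)/C=C/CNc1ccc(Cl)c(S(=O)(=O)N(C)C)c1` gives > 30000 nM as a limit, not a number. Compound 3 `C=CC(=O)N(CC(=O)OC)c1nc(-c2ccccc2)cs1` also gives > 30000 nM as a limit, not a number. Compound 4 `C=CC(=O)N(CC(=O)N1CCOCC1)c1nc(-c2ccccc2)cs1` differs from compound 3 in one place, with morpholin-4-yl in place of methoxy on a carbonyl carbon. Among the compounds with values here, the only measured step, an at least 1.2-fold higher number from compound 1 to compound 2 (0.08 log units; that floor lies within the scatter), involves a different change, so it offers little guidance. What remains is the limit of > 30000 nM in this assay, at which 2 of the 3 values shown sit, and this gives no sign of a shift in either direction. The expected outcome, an at least 1.1-fold lower number from compound 3 to compound 4 (0.04 log units; that floor lies within the scatter), is therefore no step beyond the scatter. For compound 4 the estimated value is 27000 nM, with an expected range from 10000 nM to 40000 nM.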

Compound 4, half-maximal inhibitory concentration: 14600 nM
Compound 4: the middle estimate sits 1.8-fold (0.27 log units) above what was measured; the range from low to high includes it.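

In this assay, morpholin-4-yl in place of methoxy on a carbonyl carbon brings a clear gain: an at least 2.0-fold lower number from compound 3 to compound 4 (0.31 log units; beyond the scatter). This is the first step shown that goes beyond the scatter, so the group on this carbonyl carbon does matter to the read-out. On these data alone, the true size of the gain stays unknown because compound 3 has only a limit, not a number: the limit of > 30000 nM in this assay, at which 2 of the 4 values shown sit.

As far as these compounds go, whether the gain needs the whole morpholine ring remains open. A piperidin-1-yl group or a carboxylic acid at this place would help to tell.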